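This account rests on a few compounds, and the source may have more. Where it says the series, first, only, none or still open, it means among the compounds named here.

Compound 2 `CCOc1ccc(/N=C/C2=C3NC=C(C(=O)O)C(=O)N3C(C)CC2)cc1` gives 8.96 umol/kg in a functional assay on the whole organism with Rattus norvegicus as the target (a higher number here means that more compound is needed for the effect, a lower number that less compound is needed), the lowest of the two numbers in hand; compound 1 `CC1CCN2C(=O)C(C(=O)O)=CNC2=C1/C=N/c1ccccc1C(=O)O` gives 100 umol/kg in this assay, a gap beyond the scatter. Compound 3 `CC1CCC(/C=N/c2ccc(C(F)(F)F)cc2)=C2NC=C(C(=O)O)C(=O)N21` carries trifluoromethyl in place of ethoxy on an aromatic carbon. Among the measured compounds shown here, no pair of measured compounds differs in this one place, so no measured step shows the size of such a change. Only a step near the scatter is expected, a 1.7-fold higher number from compound 2 to compound 3 (0.22 log units; within the scatter), upward in the dose if anything. Compound 3 is therefore expected to give 15 umol/kg in this assay, within a range from 5 umol/kg to 50 umol/kg.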

Compound 3, dose for 50% inhibition: > 100 umol/kg
Compound 3 was reported as a limit (the forecaster's own chance of this, stated with the estimate: 10%); middle value at least 6.6-fold (0.82 log units) away from the limit.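

Trifluoromethyl in place of ethoxy on this aromatic carbon gives an at least 11-fold higher number from compound 2 to compound 3 (1.04 log units; beyond the scatter), the first measured sign that the dose in this assay responds strongly to the group at this position. Compound 3 stands at > 100 umol/kg, which is a limit of the assay and not a number. The size of the step is therefore only a lower bound: the limit of > 100 umol/kg in this assay, at which 1 of the 3 values shown sits.

On these data alone, how far compound 3 lies past that limit stays open. Among the compounds shown here, with only two groups compared at this position, it is also open how methoxy, a longer alkoxy chain or an amine would fall.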